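Swapping the pivaloyl cap for a dinitrophenyl group

This account rests on a few compounds, and the source may have more. Where it says the series, first, only, none or still open, it means among the compounds named here.

Compound 1 `CCCCOC(=O)CNC(=O)[C@H](CSc1ccc([N+](=O)[O-])cc1[N+](=O)[O-])NC(=O)CC[C@H](NC(=O)C(C)(C)C)C(=O)OCCCC` gives 83.4 uM in a toxicity assay on KB cells (Homo sapiens) for cytotoxicity, read by fluorescence, with a stated time of 3 days; a lower number here means that less compound is needed, a higher number that more compound is needed for the effect.
Compound 2 `CCCCOC(=O)CNC(=O)[C@H](CSc1ccc([N+](=O)[O-])cc1[N+](=O)[O-])NC(=O)CC[C@H](NC(=O)C(C)C)C(=O)OCCCC` is reported only as a limit in this assay, > 300 uM.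
Compound 3 `CCCCCCCCCCCCCC(=O)N[C@@H](CCC(=O)N[C@@H](CSc1ccc([N+](=O)[O-])cc1[N+](=O)[O-])C(=O)NCC(=O)OCCCC)C(=O)OCCCC` likewise reaches only the limit of this assay, > 300 uM.

Among these three, compound 1 is the only one with an actual number; the other two sit at the limit of > 300 uM in this assay, at which 2 of the 3 values shown sit, so they give no number to compare with.

The unmeasured compound 4 `CCCCOC(=O)CNC(=O)[C@H](CSc1ccc([N+](=O)[O-])cc1[N+](=O)[O-])NC(=O)CC[C@H](Nc1ccc([N+](=O)[O-])cc1[N+](=O)[O-])C(=O)OCCCC` differs from compound 1 in one place: 2,4-dinitrophenyl in place of (tert-butyl)carbonyl on an amine nitrogen. The change is made on the amine nitrogen of the shared core, where a small branched cap is replaced by an aromatic group carrying two nitro substituents.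

Going by the values given here, no measured step matches this change. The closest comparison is an at least 3.5-fold higher number from compound 1 to compound 2 (0.55 log units; beyond the scatter), where trimming the cap pushed the value out to the limit. That step concerns a shrinking of the cap, whereas compound 4 enlarges it, so it gives no direction for the new group. With nothing more to lean on, a step close to the scatter is expected, with the limit of this assay remaining a real possibility. Compound 4 is therefore estimated at 70 uM, within 15 uM to 300 uM, which is a step of a 1.2-fold lower number from compound 1 to compound 4 (0.08 log units; within the scatter).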

Compound 4, concentration for half-maximal effect: > 300 uM
Compound 4 ended at the assay's limit; the forecaster's own chance of this, stated with the estimate: 30%; at least 4.2-fold (0.63 log units) between middle value and limit.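

Placing 2,4-dinitrophenyl instead of (tert-butyl)carbonyl on the amine nitrogen gives an at least 3.5-fold higher number from compound 1 to compound 4 (0.55 log units; beyond the scatter) in this assay. This group has more heavy atoms and an aromatic ring, yet the value moves the same way as with the smaller isopropylcarbonyl group, seen in an at least 3.5-fold higher number from compound 1 to compound 2 (0.55 log units; beyond the scatter), so among these compounds the measured value of compound 1, 83.4 uM, does not follow group size in a single direction. The value of compound 4, > 300 uM, is a limit and not a number, and the step between compound 2 and compound 4, which joins two limits, cannot be read.

How far compound 2 and compound 4 lie past the limit stays unknown, and compound 1 remains the only compound with a number: the limit of > 300 uM in this assay, at which 3 of the 4 values shown sit.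

As far as these compounds go, whether a plain phenyl group without the two nitro groups, or a cap carrying an amine or a carboxylic acid, would give a measurable value on this nitrogen stays open.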